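The compounds below may be only part of what the source reports. "The series", "measured", "known", "first", "only" and "open" are said of these compounds alone.

Compound 1 `C=C(CCc1cc(O)c2c(=O)cc(-c3ccccc3)oc2c1)Cc1c(Br)cccc1C(=O)CC`: 40700 nM
Compound 2 `COC(=O)c1cccc(OC)c1OC(=O)COc1cc(O)c2c(=O)cc(-c3ccccc3)oc2c1`: 36800 nM
Compound 3 `COC(=O)c1ccc(Cl)cc1OC(=O)COc1cc(O)c2c(=O)cc(-c3ccccc3)oc2c1`: 12400 nM

Of the compounds shown here, three built on a shared core have been tested in a functional assay on cells (T-cell, Mus musculus, strain BALB/c) for inhibition, read by MTT assay, with a stated time of 72 h; a higher number here means a weaker inhibitor, a lower number a stronger inhibitor. Compound 3 gives the lowest number of the three. Its nearest neighbour is compound 2, whose number lies higher by a gap beyond the usual scatter, and compound 1 sits further off again, also beyond the scatter. Compound 3 is therefore the strongest inhibitor among the measured compounds.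

Compound 4 `COC(=O)c1c(Cl)cccc1OC(=O)COc1cc(O)c2c(=O)cc(-c3ccccc3)oc2c1` has not been measured yet. It holds the same atoms as compound 3, joined differently: 3-chloro-2-(methoxycarbonyl)phenyl in place of 5-chloro-2-(methoxycarbonyl)phenyl on an oxygen next to a carbonyl group. The chlorine and the methoxycarbonyl group both remain on the ring, but the chlorine now sits at a different point of it. Among the measured compounds shown here, no pair of measured compounds shows a move of this kind, so there is no earlier step to lean on.

With so little to go on, a change of this size in this assay is expected to fall within the scatter, in either direction. Compound 4 is therefore expected to give about 15000 nM in this assay, with a range from 6000 nM to 40000 nM. This estimate means a step of a 1.2-fold higher number from compound 3 to compound 4 (0.08 log units; within the scatter), expected to stay within the scatter.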

Compound 4, half-maximal inhibitory concentration: 38900 nM
Compound 4: the middle estimate sits 2.6-fold (0.41 log units) below what was measured, within the range that was stated.
By their numbers in this assay, from the lowest: compound 3; then compounds 2, 4 and 1 (each within the scatter of the next).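

In this assay, moving the chlorine alone, with 3-chloro-2-(methoxycarbonyl)phenyl in place of 5-chloro-2-(methoxycarbonyl)phenyl on the same oxygen, gives a 3.1-fold higher number from compound 3 to compound 4 (0.50 log units; beyond the scatter), a modest step but one beyond the scatter, which makes compound 4 the weaker inhibitor of this pair. Among the compounds shown here, the earlier compounds differed from one another in more than one place, so this is the first direct sign that the result depends on where the chlorine sits on this ring, even when the atoms of the two groups are the same and every feature counted for them matches. Nothing measured here accounts for the difference between the two arrangements.

This is a single pair, so it cannot show whether the same sensitivity would appear with another group, such as fluorine or a nitrile, in place of the chlorine. It also leaves open whether the difference would survive if a carboxylic acid or an amide replaced the methoxycarbonyl group, or if the ring carried the chlorine alone.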